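A Trifluoromethyl Added to an Inactive Pair

The source may report more compounds than this note shows. Statements on the series, on what has been measured and on what is new or still open speak of the compounds shown alone.

Compound 1 `C#CCOC(c1cccs1)c1cc2ccccc2nc1Cl`: > 100000 nM
Compound 2 `Clc1nc2ccccc2cc1C(OCc1ccccc1)c1cccs1`: "not active" (no number reported)

In a functional assay on HCT-116 cells (Homo sapiens) for inhibition, read by WST assay, with stated times of 72 h and 2 h (a higher number here means a weaker inhibitor, a lower number a stronger inhibitor), compound 1 gives > 100000 nM, which is a limit of the assay rather than a number. Compound 1 accounts for (the limit of > 100000 nM in this assay, at which 1 of the 2 values shown sits). In this assay compound 2 is reported as "not active" (no number reported), so no number places it on the scale. Compound 3 `FC(F)(F)c1cccc(COC(c2cccs2)c2cc3ccccc3nc2Cl)c1` differs from compound 2 by trifluoromethyl in place of hydrogen on an aromatic carbon. Among the compounds with values here, no measured step exists between these compounds, so in this assay I expect no change beyond the scatter from compound 2 to compound 3, with a high chance of only a limit. Compound 3 is expected to give 100000 nM, between 20000 nM and 300000 nM.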

Compound 3, half-maximal inhibitory concentration: "not active" (no number reported)
The entry for compound 3 holds no number; no gap can be computed for the estimate.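

Neither compound 2 nor compound 3 has a number in this assay, so no step can be read between them. Still open is how far either compound lies from a measurable value, as the only figure shown is a limit: the limit of > 100000 nM in this assay, at which 1 of the 3 values shown sits.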